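The compounds below may be only part of what the source reports. "The series", "measured", "known", "first", "only" and "open" are said of these compounds alone.

Compound 1 `O=C(Nc1cccc(-n2cc(-c3ccncc3)c(-c3ccc(Cl)c(O)c3)n2)c1)Nc1cccc(C(F)(F)F)c1` is the starting point of this comparison. In a functional assay on SN12C cells (Homo sapiens) for inhibition, read by sulforhodamine B assay, with a stated time of 48 h (on this read-out higher numbers stand for lower toxicity in this test and lower numbers for higher toxicity in this test), compound 1 gives > 32500 nM, which is a limit of the assay and not a number. Compound 2 `O=C(Nc1cccc(-n2cc(-c3ccncc3)c(-c3ccc(Cl)c(O)c3)n2)c1)Nc1ccc(Cl)c(Cl)c1` differs from compound 1 by 3,4-dichlorophenyl in place of 3-(trifluoromethyl)phenyl on an amide-type nitrogen. In this assay compound 2 gives > 32500 nM, again a limit. Compound 3 `COc1cc(-c2nn(-c3cccc(NC(=O)Nc4cccc(C(F)(F)F)c4)c3)cc2-c2ccncc2)ccc1Cl` carries methyl in place of hydrogen on an oxygen on an aromatic ring. In this assay compound 3 gives > 50000 nM, also a limit. Accordingly the step that the two limits leave unreadable from compound 1 to compound 2 and the step that the two limits leave unreadable from compound 1 to compound 3 cannot be read in size, with the limit of > 32500 nM in this assay, at which 2 of the 3 values shown sit, and the limit of > 50000 nM in this assay, at which 1 of the 3 values shown sits, marking where the three values sit. Within the data shown here, compound 1 therefore stands at a limit, and no compound in the set is separated from it by a readable step.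

Compound 4 `O=C(Nc1cccc(-n2cc(-c3ccncc3)c(-c3ccc(Cl)c(O)c3)n2)c1)Nc1cc(C(F)(F)F)cc(C(F)(F)F)c1` is the unmeasured compound. The change from compound 1 is trifluoromethyl in place of hydrogen on an aromatic carbon. Both measured steps from compound 1 are unreadable, so nothing points to a step beyond the scatter in this assay in either direction, and the expectation is that compound 4 will also sit at the limit. On that basis compound 4 is estimated at 40000 nM in this assay, within 20000 nM to 100000 nM. The estimated step is a step that the limit leaves unreadable from compound 1 to compound 4.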

Compound 4, concentration lethal to 50% of the cells: > 50000 nM
Compound 4: only a limit was reported (the forecaster's own chance of this, stated with the estimate: 75%); middle value at least 1.2-fold (0.09 log units) from the limit.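

Compound 1 and compound 4 both stand at limits in this assay, and the step between them cannot be read in size. The compounds shown leave open whether any of these changes, trifluoromethyl in place of hydrogen included, alters the lethal concentration at all; every value shown is a limit and not a number.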